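A few compounds are considered here, and "the series" means these few. Any claim that something is new, unique, unknown or untested is made for them only; others in the source may bear on it.

Measured compounds:
- compound 1 `O[C@@H]1[C@@H](O)CN[C@H]1c1ccccc1`: 2.6%
- compound 2 `Cc1ccc([C@@H]2NC[C@H](O)[C@H]2O)cc1`: 0%

Among the measured compounds shown here, in an assay on isolated protein for inhibition of alpha-galactosidase (Coffea arabica), read by spectrophotometry, tested at 1000 uM (on this read-out higher numbers stand for more inhibition at the one concentration tested (going by the name of the read-out) and lower numbers for less inhibition), compound 2 sits alongside compound 1, the only other number, and the pair is separated by a number 2.6 percentage points lower from compound 1 to compound 2 (within the scatter). Compound 3 `Cc1ccc([C@H]2NC[C@@H](O)[C@@H]2O)cc1` keeps every atom and bond of compound 2: the two compounds have the same atoms and bonds and differ only in configuration as drawn: 3 of 3 stereo elements differ (all stereocentres are inverted: mirror images); a stereocentre at a saturated ring carbon is drawn S in compound 2 and R in compound 3; a stereocentre at a saturated ring carbon is drawn S in compound 2 and R in compound 3; a stereocentre at a saturated ring carbon is drawn S in compound 2 and R in compound 3. For the measured compounds named here, no measured step concerns a change of configuration; the single measured step is the methyl in place of hydrogen and gives no guidance on mirror images. With both numbers low, compound 3 is expected to show a number 5 percentage points higher from compound 2 to compound 3 (within the scatter), a step not beyond the scatter. Compound 3 is therefore estimated at 5%, within 0% to 30%.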

Compound 3, a percentage reported as inhibition, at one concentration (the size of the read-out at that concentration, not a potency): 0%
Beside the measured number, compound 3's estimate is 5 percentage points above it, within the range that was stated.
By their numbers in this assay, from the lowest: compounds 2, 3 and 1 (each within the scatter of the next).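

In this assay, inverting all three stereocentres gives no change at the digits printed from compound 2 to compound 3 (within the scatter), the first view of configuration in this series. With the methyl on the aromatic carbon kept, the mirror-image change therefore separates nothing at the one concentration tested. The pair isolates that single change: the fact that compounds 2 and 3 differ only in the configuration as drawn.

Since both numbers lie at the bottom of the read-out, any preference between mirror images could stay hidden. From the compounds shown here alone, whether an amine or a carboxylic acid in place of the methyl would give measurable inhibition, and make configuration count, stays open.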